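The compounds below may be only part of what the source reports. "The series", "measured", "known", "first", "only" and "open" are said of these compounds alone.

Measured compounds:
Compound 1 `COc1ccc(-n2cc(-c3ccccc3)c(-c3ccc4c(c3)NC(=O)CO4)n2)cc1`: 42.6%
Compound 2 `O=C1COc2ccc(-c3[nH]c(-c4ccccc4)nc3-c3ccccc3)cc2N1`: 58.5%

Both compounds were tested in a functional assay on A549 cells (Homo sapiens) for cytotoxicity, read by colorimetric assay and MTT assay, with a stated time of 3 days, tested at 20 uM; on this read-out lower numbers stand for a stronger effect and higher numbers for a weaker effect at the one concentration tested. Compound 1 gives 42.6%, the lowest of the two numbers, and compound 2 gives 58.5%, a number that lies beyond the usual scatter above compound 1. The two compounds differ in more than one place, so their values show only where each stands, not what any single change does.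

Compound 3 `Cc1ccccc1-n1cc(-c2ccccc2)c(-c2ccc3c(c2)NC(=O)CO3)n1` has not been measured. It differs from compound 1 in one place: 2-methylphenyl in place of 4-methoxyphenyl on an aromatic nitrogen. For the measured compounds named here, no measured pair shows what a change of this kind does here, so the direction of the step is open. Swapping one small aromatic group for another on the same ring nitrogen seems likely to move the number only a little, so the expected step from compound 1 is a number 5.4 percentage points higher from compound 1 to compound 3 (within the scatter), with no clear direction beyond the scatter. For compound 3 the estimated value is 48%, expected to fall between 30% and 68%.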

Compound 3, a percentage reported as activity, at one concentration (the size of the read-out at that concentration, not a potency): 85.3%
Estimate against measurement, compound 3: 37.3 percentage points below, outside the stated range (above it).
By their numbers in this assay, from the lowest: compound 1; then compound 2; then compound 3.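

In this assay, putting 2-methylphenyl in place of 4-methoxyphenyl on the aromatic nitrogen gives a number 42.7 percentage points higher from compound 1 to compound 3 (beyond the scatter) at the one concentration tested, which here means a much weaker effect. For the compounds shown here, this is the first pair that differs in only one place, and it shows that the group on this nitrogen matters: exchanging one single-ring aromatic group for another can move the number well beyond the scatter. Nothing measured here explains why the step is so large.

The change alters both the group on the ring and where it sits, so the compounds shown cannot separate those two effects. Compounds with 4-methylphenyl or 2-methoxyphenyl on this nitrogen could separate them, while an amine or a carboxylic acid on the ring would test a different kind of group.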